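This account rests on a few compounds, and the source may have more. Where it says the series, first, only, none or still open, it means among the compounds named here.

Measured so far:
Compound 1 `C=CC1=C(C(=O)NC2CCCCC2)C(c2ccc(OC)cc2)OC1` gives > 100000 nM in a functional assay on A549 cells (Homo sapiens) for cytotoxicity, read by MTT assay, with a stated time of 24 h (a lower number here means a stronger inhibitor, a higher number a weaker inhibitor), which is a limit of the assay.
Compound 2 `C=CC1=C(C(=O)NCc2ccc(Cl)cc2)C(c2ccc(OC)cc2)OC1` gives > 100000 nM in this assay, again a limit of the assay.
Compound 3 `C=CC1=C(C(=O)NCC(C)C)C(c2ccc(OC)cc2)OC1` gives > 100000 nM in this assay, also a limit of the assay.

Compound 3 therefore stands only at a limit, and the two other values shown are limits as well. Compound 4 `C=CC1=C(C(=O)NCc2ccccc2F)C(c2ccc(OC)cc2)OC1` differs from compound 3 by 2-fluorophenyl in place of isopropyl on a saturated chain carbon bound to an amide-type nitrogen; cut one bond further out, the change reads isobutyl to 2-fluorobenzyl. The measured steps that bear on this are a step that the two limits leave unreadable from compound 1 to compound 3, a step that the two limits leave unreadable from compound 1 to compound 2 and a step that the two limits leave unreadable from compound 2 to compound 3, and none of them has a readable size, because of the limit of > 100000 nM in this assay, at which 3 of the 3 values shown sit. Exchanging one amide substituent for another of this kind has so far not produced any number at all. The step from compound 3 to compound 4 is thus expected to be a number no higher from compound 3 to compound 4 (the limit leaves the size open), nothing beyond the scatter. Compound 4 is expected to give about 100000 nM in this assay, with a range from 40000 nM to 300000 nM, most likely again reported only as a limit.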

Compound 4, half-maximal inhibitory concentration: > 100000 nM
Compound 4: only a limit was reported; the forecaster's own chance of this, stated with the estimate: 85%; the middle value sits exactly at the limit.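

The steps linking compound 4 to compound 1, compound 2 and compound 3 cannot be read, because all four compounds share one assay limit: the limit of > 100000 nM in this assay, at which 4 of the 4 values shown sit.

The compounds shown leave open whether any amide substituent on the shared core changes cytotoxicity enough to give an actual number.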